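The compounds below may be only part of what the source reports. "The series", "measured", "known", "first", "only" and "open" are said of these compounds alone.

Compound 1 `N#Cc1c(-c2cccc(Cl)c2)c(C#N)c(=O)n(/N=C/c2cn(-c3ccccc3)nc2-c2ccccc2)c1N` was examined in an ADME assay on HeLa cells (Homo sapiens) for cytotoxicity, read by MTT assay; a higher number here means a weaker inhibitor, a lower number a stronger inhibitor. In that assay compound 1 gives > 200 ug/mL, which is a limit of the assay rather than a number. Compound 2 `N#Cc1c(-c2ccc(Cl)cc2)c(C#N)c(=O)n(/N=C/c2cn(-c3ccccc3)nc2-c2ccccc2)c1N` carries 4-chlorophenyl in place of 3-chlorophenyl on an aromatic carbon, and in this assay compound 2 gives > 200 ug/mL, again a limit. Compound 3 `N#Cc1c(-c2ccccc2Br)c(C#N)c(=O)n(/N=C/c2cn(-c3ccccc3)nc2-c2ccccc2)c1N` carries 2-bromophenyl in place of 3-chlorophenyl on an aromatic carbon, and in this assay compound 3 gives > 200 ug/mL, also a limit. Because (the limit of > 200 ug/mL in this assay, at which 3 of the 3 values shown sit), the steps a step that the two limits leave unreadable from compound 1 to compound 2, a step that the two limits leave unreadable from compound 1 to compound 3 and a step that the two limits leave unreadable from compound 2 to compound 3 cannot be sized. Compound 4 `N#Cc1c(-c2ccc(Br)cc2)c(C#N)c(=O)n(/N=C/c2cn(-c3ccccc3)nc2-c2ccccc2)c1N` differs from compound 1 by 4-bromophenyl in place of 3-chlorophenyl on an aromatic carbon. All three measured steps bear on this change, since each swaps one halogenated phenyl for another at the same aromatic carbon, yet none gives a readable size. Compound 1 sits only at a limit, and compound 4 is expected to behave alike, so the step that the limit leaves unreadable from compound 1 to compound 4 is expected to be none beyond the scatter. Compound 4 is thus estimated at 250 ug/mL, within 120 ug/mL to 500 ug/mL.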

Compound 4, half-maximal inhibitory concentration: > 200 ug/mL
Compound 4: a limit, no number (the forecaster's own chance of this, stated with the estimate: 85%); the middle value does not contradict the limit.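

In this assay compound 4 gives > 200 ug/mL, a limit and not a number. Its steps from compound 1, compound 2 and compound 3 cannot be read: the limit of > 200 ug/mL in this assay, at which 4 of the 4 values shown sit. The compounds shown leave open whether exchanging these halogenated phenyl groups changes the result in this assay at all.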